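Replacing furan-2-yl on a carbonyl carbon

The compounds below may be only part of what the source reports. "The series", "measured", "known", "first", "only" and "open" are said of these compounds alone.

In an ADME assay on L929 cells (Mus musculus) for cytotoxicity, read by resazurin assay, with a stated time of 72 h (on this read-out higher numbers stand for weaker inhibition and lower numbers for stronger inhibition), compound 1 (`O=C(/C=C/c1ccc2c(c1)B(O)OC2)c1ccco1`) gives > 10 ug/mL as its result, and this is a limit of the assay and not a number. Compound 2 (`COc1cccc(C(=O)CCc2ccc3c(c2)B(O)OC3)c1`) gives > 10 ug/mL as its result, again a limit. Going by the values given here, the whole record so far is therefore the limit of > 10 ug/mL in this assay, at which 2 of the 2 values shown sit, and no measured step exists between the two compounds.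

Compound 3 (`Cc1cccc(C(=O)/C=C/c2ccc3c(c2)B(O)OC3)c1`) has not yet been measured. It carries 3-methylphenyl in place of furan-2-yl on a carbonyl carbon and shares the core of compound 1.

The expected step that the limit leaves unreadable from compound 1 to compound 3 lies within the usual scatter of this assay and no direction is favoured. A report as a limit is the likeliest outcome. The estimate for compound 3 is 14 ug/mL (expected range 6 ug/mL to 35 ug/mL).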

Compound 3, half-maximal inhibitory concentration: 8.56 ug/mL
For compound 3 the middle estimate is 1.6-fold (0.21 log units) above the measured one; low and high end bracket the measured number.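

In this assay, going by these compounds alone, compound 3 gives 8.56 ug/mL, the only value shown that is a number and not a limit. Placing 3-methylphenyl in place of furan-2-yl on a carbonyl carbon gives an at least 1.1-fold lower number from compound 1 to compound 3 (0.06 log units; that floor lies within the scatter), so the data show no shift beyond the scatter, although the step has only a floor and its real size cannot be read. The series therefore gains one number at this position, while most of the record remains a limit: the limit of > 10 ug/mL in this assay, at which 2 of the 3 values shown sit.

On these data alone, the true size of the step stays open, since the value for compound 1 is a limit. Also open, as far as these compounds go, is how an amine or a carboxylic acid in place of furan-2-yl on a carbonyl carbon would read in this assay.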